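From hexyloxy to 2-ethoxyethoxy on the shared core

This account rests on a few compounds, and the source may have more. Where it says the series, first, only, none or still open, it means among the compounds named here.

The series is read in an ADME assay on RAW264.7 cells (Mus musculus) for cytotoxicity, read by MTT assay, with a stated time of 24 h, in the presence of a further agent that is not named here; on this read-out lower numbers stand for stronger inhibition and higher numbers for weaker inhibition. Compound 1 `Cc1noc(CC2OC(=O)c3ccccc32)n1` gives > 40000 nM, which is a limit of the assay. Compound 2 `CCOc1ccc(C(O)C2OC(=O)c3c(OC)cc(OC)cc32)cc1` gives > 40000 nM, also a limit. Compound 3 `CCCCCCOc1ccc(C(O)C2OC(=O)c3c(OC)cc(OC)cc32)cc1`, the hexyloxy member, gives > 40000 nM, again a limit, so it has no numerical place in the series. The evidence so far comes down to the limit of > 40000 nM in this assay, at which 3 of the 3 values shown sit.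

Compound 4 `CCOCCOc1ccc(C(O)C2OC(=O)c3c(OC)cc(OC)cc32)cc1` has not yet been measured. Its difference from compound 3 is ethoxy in place of butyl on a saturated chain carbon, two bonds along the chain from an oxygen on an aromatic ring, which, cut further out, reads hexyloxy to 2-ethoxyethoxy. Going by the values given here, the one measured step at this place on the chain is a step that the two limits leave unreadable from compound 2 to compound 3, which introduced the butyl that ethoxy now replaces. With compound 2 and compound 3 both within (the limit of > 40000 nM in this assay, at which 3 of the 3 values shown sit), no size can be carried over from that step, and compound 4 is expected to sit at the limit too.

The expected change in this assay is a step that the limit leaves unreadable from compound 3 to compound 4, with no step beyond the scatter and no direction expected. For compound 4 the estimate is 45000 nM, with an expected range of 25000 nM to 80000 nM, and a report of only a limit is the likeliest outcome.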

Compound 4, half-maximal inhibitory concentration: > 40000 nM
Compound 4 was reported as a limit; the forecaster's own chance of this, stated with the estimate: 90%; the middle value lies beyond the limit too.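

In this assay, going by these compounds alone, compound 4 gives > 40000 nM, a limit, so no step from compound 2 or compound 3 to compound 4 can be read. The series offers only one result: the limit of > 40000 nM in this assay, at which 4 of the 4 values shown sit.

The compounds shown leave open whether any change on the shared core would give a numerical value in this assay.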